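Dog liver microsomal stability of the aryl variants

This account rests on a few compounds, and the source may have more. Where it says the series, first, only, none or still open, it means among the compounds named here.

Compound 1 `Nc1nc(NCCNc2ncc(-c3ncc[nH]3)c(-c3ccc(C(F)(F)F)cc3)n2)ccc1[N+](=O)[O-]`: in an ADME assay on microsomes from liver (Canis lupus familiaris) for metabolic stability (on this read-out lower numbers stand for a shorter-lived compound and higher numbers for a longer-lived compound), compound 1 gives > 0.5 h, which is a limit of the assay.
Compound 2 `Nc1nc(NCCNc2ncc(-c3ncc[nH]3)c(-c3ccccc3Cl)n2)ccc1[N+](=O)[O-]`: in this assay compound 2 gives > 0.5 h, again a limit of the assay.
Compound 3 `Nc1nc(NCCNc2ncc(-c3ncc[nH]3)c(-c3ccc(F)cc3Br)n2)ccc1[N+](=O)[O-]`: in this assay compound 3 gives > 0.5 h, also a limit of the assay.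

Compound 2 therefore stands only at a limit, and the two further values shown are limits as well; all three sit at the limit of > 0.5 h in this assay, at which 3 of the 3 values shown sit. Going by the values given here, because of the limit of > 0.5 h in this assay, at which 3 of the 3 values shown sit, none of the measured steps can be read: a step that the two limits leave unreadable from compound 1 to compound 2, a step that the two limits leave unreadable from compound 1 to compound 3 and a step that the two limits leave unreadable from compound 2 to compound 3 are all left unreadable by the two limits.

Compound 4 `Nc1nc(NCCNc2ncc(-c3ncc[nH]3)c(-c3ccc(Cl)cc3F)n2)ccc1[N+](=O)[O-]` differs from compound 2 by 4-chloro-2-fluorophenyl in place of 2-chlorophenyl on an aromatic carbon. Among the compounds with values here, the steps that bear on this change are those that touch the 2-chlorophenyl, from compound 1 to compound 2 and from compound 2 to compound 3, and both are unreadable, so their size is not known. No readable step exists on which a direction could be based. The step that the limit leaves unreadable from compound 2 to compound 4 is therefore expected to be no step beyond the scatter relative to the limit at which compound 2 sits. Compound 4 is estimated at 1 h, within a range of 0.4 h to 3 h, with a high chance that the assay again reports only a limit.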

Compound 4, half-life: > 0.5 h
Compound 4 ended at the assay's limit; the forecaster's own chance of this, stated with the estimate: 80%; the middle value is on the limit's open side.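

The steps from compound 1, compound 2 and compound 3 to compound 4 cannot be read, because all four compounds stop at the same limit in this assay: the limit of > 0.5 h in this assay, at which 4 of the 4 values shown sit.

The compounds shown leave open the actual half-life of each aryl variant in this assay, and whether swapping these aryl groups changes it at all.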